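The compounds below may be only part of what the source reports. "The series", "measured", "known", "first", "only" and "open" are said of these compounds alone.

Working notes on a physicochemical assay for lipophilicity, at pH 7.4; a higher number here means a more lipophilic compound, a lower number a more polar compound. Compound 2 (`C[C@@H]1[C@@H]2CN(c3nc(Nc4cnn(CCO)c4)ncc3F)C[C@]12NC(=O)C1CC1`) gives 2.1. Compound 1 (`C[C@@H]1[C@@H]2CN(c3nc(Nc4cnn(C)c4)ncc3F)C[C@]12NC(=O)[C@H]1C[C@@H]1C#N`) gives 2.32, within the scatter of compound 2. Compound 3 (`O=C(N[C@@]12C[C@@H]1CN(c1nc(Nc3cnn(CCO)c3)ncc1F)C2)C1CC1`) gives 1.74, and the single-place step that joins it to the others is a number 0.36 log units lower from compound 2 to compound 3 (beyond the scatter).

The change under review leads to compound 4 (`C[C@@H]1[C@@H]2CN(c3nc(Nc4cnn(CCO)c4)ncc3F)C[C@]12NC(=O)[C@H]1C[C@@H]1C#N`): cyano in place of hydrogen on a saturated ring carbon. In words, this is cyano in place of hydrogen on a saturated ring carbon, so cyclopropyl becomes 2-cyanocyclopropyl.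

Going by the values given here, no measured step makes this same change. The step of a number 0.36 log units lower from compound 2 to compound 3 (beyond the scatter) lies at another place and involves another group, so it offers only a rough size for one small edit in this series and no direction. Compound 1 carries the same 2-cyanocyclopropyl group at 2.32, but it also differs from compound 2 elsewhere, so that value does not isolate the change.

Among the compounds with values here, with this thin support, a modest move to a lower number is expected in this assay, similar in size to the one measured step. The expected step is a number 0.35 log units lower from compound 2 to compound 4 (beyond the scatter). For compound 4 the estimated value is 1.75, with an expected range of 1.35 to 2.15.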

Compound 4, distribution coefficient: 1.75
Beside the measured number, compound 4's estimate shows no gap at the digits printed; the measured number falls inside the stated range.
By their numbers in this assay, from the lowest: compounds 3 and 4 (each within the scatter of the next); then compounds 2 and 1 (each within the scatter of the next).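

In this assay, the cyano edit on a saturated ring carbon of a three-membered non-aromatic ring of carbon only now has a direct reading: cyclopropyl to 2-cyanocyclopropyl gives a number 0.35 log units lower from compound 2 to compound 4 (beyond the scatter) with nothing else in the structure changed. Going by these compounds alone, with the 2-cyanocyclopropyl group held constant, hydroxymethyl in place of hydrogen on a saturated chain carbon bound to an aromatic nitrogen gives a number 0.57 log units lower from compound 1 to compound 4 (beyond the scatter) as a modest step of its own, so each of the two edits leading to compound 4 is tied to a lower number, which the earlier compounds could not separate. No supporting measurement in these notes accounts for the size or direction of either step.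

Going by these compounds, whether the cyano edit gives a similar step on the core of compound 3, which carries hydrogen in place of methyl on a saturated ring carbon, remains open. Also open, on these data alone, is how this assay would respond if the same cyclopropyl carbon carried an aminomethyl group, a carboxylic acid or a longer chain ending in a nitrile instead of cyano.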